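Chloro in place of fluoro: compound 2 to compound 3

This account rests on a few compounds, and the source may have more. Where it says the series, first, only, none or still open, it means among the compounds named here.

In a functional assay on SK-BR-3 cells (Homo sapiens) for antiproliferative activity, read by MTT assay, with a stated time of 72 h (on this read-out higher numbers stand for weaker inhibition and lower numbers for stronger inhibition), compound 1 (`CCN1CCN(c2cc(C)c3cc(NC(=O)c4cccc(Cl)c4)ccc3n2)CC1`) gives 17800 nM, and compound 2 (`CCN1CCN(c2cc(C)c3cc(NC(=O)c4ccccc4F)ccc3n2)CC1`) gives 38100 nM, the higher of the two numbers. Compound 3 (`CCN1CCN(c2cc(C)c3cc(NC(=O)c4ccccc4Cl)ccc3n2)CC1`) differs from compound 2 in one place: chloro in place of fluoro on an aromatic carbon, with chloro in place of fluoro on an aromatic carbon, ortho to a large group. Among the measured compounds shown here, one measured step bears on this: a 2.1-fold higher number from compound 1 to compound 2 (0.33 log units; beyond the scatter), modest and beyond the scatter. That step, 2-fluorophenyl in place of 3-chlorophenyl, changes the halogen and its place together, so it gives only weak guidance on the present change. A small step toward a lower number in this assay is therefore expected, possibly no larger than the scatter: a 1.5-fold lower number from compound 2 to compound 3 (0.17 log units; within the scatter) is the estimate. For compound 3 the expected value is 26000 nM, with an estimated range of 12000 nM to 52000 nM.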

Compound 3, half-maximal inhibitory concentration: > 50000 nM
Compound 3 gave a limit, no number; the forecaster's own chance of this, stated with the estimate: 10%; at least 1.9-fold (0.28 log units) between middle value and limit.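

Compound 3 stands at a limit of this assay, not at a number: the limit of > 50000 nM in this assay, at which 1 of the 3 values shown sits.

With the halogen held as chloro, a change of place alone, 2-chlorophenyl in place of 3-chlorophenyl, gives an at least 2.8-fold higher number from compound 1 to compound 3 (0.44 log units; beyond the scatter). This separates place from halogen, which the earlier step changed together. With the place held, chloro in place of fluoro gives an at least 1.3-fold higher number from compound 2 to compound 3 (0.11 log units; that floor lies within the scatter), so this change brings no lower number here, although its size remains unsettled.

From the compounds shown here alone, whether the change from fluoro to chloro exceeds the scatter stays open. Also open, going by these compounds, is whether a bromo or methoxy group on the same aromatic carbon, or 3-fluorophenyl on the carbonyl carbon, would give a lower number.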